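This account rests on a few compounds, and the source may have more. Where it says the series, first, only, none or still open, it means among the compounds named here.

Measured compounds:
Compound 1, `C[C@H](CS[C@@H](CCc1ccccc1CC(C)(C)O)c1cccc(/C=C/c2ccc3ccc(Cl)cc3n2)c1)C(=O)O`, gives 33 mL/min/kg in an in vivo ADME assay on the whole organism (plasma) for pharmacokinetics, with Rattus norvegicus as the target, at a dose of 5 mg/kg by the intravenous route; on this read-out higher numbers stand for fast clearance and lower numbers for slow clearance.
Compound 2, `CC(=O)c1ccccc1CC[C@H](SC[C@@H](C)C(=O)O)c1cccc(/C=C/c2ccc3ccc(Cl)cc3n2)c1`, gives 11 mL/min/kg in this assay.

Among these two numbers compound 1 stands highest, with compound 2 nearest at a 3.0-fold lower number from compound 1 to compound 2 (0.48 log units; beyond the scatter). Compound 3, `C[C@H](CS[C@@H](CCc1ccccc1C(=O)c1ccccc1)c1cccc(/C=C/c2ccc3ccc(Cl)cc3n2)c1)C(=O)O`, is not yet measured in this assay. It differs from compound 1 as follows: benzoyl in place of 2-hydroxy-2-methylpropyl on an aromatic carbon. Within the data shown here, the one measured step that bears on it is the one from compound 1 to compound 2, where an acetyl took the place of the same 2-hydroxy-2-methylpropyl on an aromatic carbon and gave a 3.0-fold lower number from compound 1 to compound 2 (0.48 log units; beyond the scatter). A benzoyl entering at that same aromatic carbon is therefore expected to move the number in the same direction, by a modest step beyond the scatter. Compound 3 is expected to give 14 mL/min/kg in this assay, with a range from 6 mL/min/kg to 30 mL/min/kg. Relative to compound 1 this estimate means an expected step of a 2.4-fold lower number from compound 1 to compound 3 (0.37 log units; beyond the scatter).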

Compound 3, clearance: 18 mL/min/kg
The estimate for compound 3 lay 1.3-fold (0.11 log units) below the measured number, within the range that was stated.
By their numbers in this assay, from the lowest: compounds 2, 3 and 1 (each within the scatter of the next, the first and the last beyond it).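

In this assay, the benzoyl of compound 3 in place of the 2-hydroxy-2-methylpropyl of compound 1 gives a step that stays within the scatter (a 1.8-fold lower number from compound 1 to compound 3 (0.26 log units; within the scatter)), whereas the acetyl gave one beyond it (a 3.0-fold lower number from compound 1 to compound 2 (0.48 log units; beyond the scatter)). Phenyl in place of methyl on the carbonyl carbon is also within the scatter (a 1.6-fold higher number from compound 2 to compound 3 (0.21 log units; within the scatter)), so compound 3 cannot be separated from either neighbour, and the two ketones cannot be told apart at this aromatic carbon. Nothing measured here accounts for these numbers.

The compounds shown leave open whether the carbonyl itself goes with the step from the tertiary alcohol to the acetyl. A secondary alcohol or a nitrile on the same aromatic carbon would bear on that question.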